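The source may hold more compounds than are shown below. What is called first, only, known or untested is meant among the compounds shown, and "the series" means these compounds.

Compound 1 `CCN1CCN(CCC(=O)Nc2nc3c(C)cccc3s2)CC1` gives 1200 nM in an assay on membranes from liver for displacement of a labelled ligand from Sigma intracellular receptor 2 (Rattus norvegicus), read by scintillation counting, with a stated time of 120 min; on this read-out lower numbers stand for stronger inhibition and higher numbers for weaker inhibition. Compound 2 `CCCCCCN1CCN(CCC(=O)Nc2nc3c(C)cccc3s2)CC1` gives 158 nM, and compound 3 `Cc1cccc2sc(NC(=O)CCN3CCN(c4ccncc4)CC3)nc12` gives 1700 nM, the highest of the three numbers, although the step of a 1.4-fold higher number from compound 1 to compound 3 (0.15 log units; within the scatter) stays within the scatter while an 11-fold higher number from compound 2 to compound 3 (1.03 log units; beyond the scatter) lies beyond it. Compound 4 `Cc1cccc2sc(NC(=O)CCN3CCN(c4ncccn4)CC3)nc12` differs from compound 3 by pyrimidin-2-yl in place of pyridin-4-yl on an amine nitrogen in a ring. For the measured compounds named here, the measured steps at this ring nitrogen, a 1.4-fold higher number from compound 1 to compound 3 (0.15 log units; within the scatter) and an 11-fold higher number from compound 2 to compound 3 (1.03 log units; beyond the scatter), each swap an alkyl group for an aromatic ring; no measured step swaps one aromatic ring for another, so there is no direct guide, and no step beyond the scatter is expected in this assay. Compound 4 is expected to give about 1700 nM, between 800 nM and 3600 nM, meaning no change at the digits printed from compound 3 to compound 4 (within the scatter).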

Compound 4, inhibition constant: > 1000 nM
Compound 4: no number, only a limit; the forecaster's own chance of this, stated with the estimate: 5%; the middle value does not contradict the limit.
By their numbers in this assay, from the lowest: compound 2; then compounds 1 and 3 (each within the scatter of the next).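

Compound 4 gives > 1000 nM in this assay, which is a limit and not a number. Even so, the change from hexyl to pyrimidin-2-yl on the ring nitrogen can be read as an at least 6.3-fold higher number from compound 2 to compound 4 (0.80 log units; beyond the scatter), so a second aromatic ring, like pyridin-4-yl in compound 3, gives a higher number than hexyl in compound 2. The steps to compound 4 from compound 1 and from compound 3 cannot be read, so the swap of one aromatic ring for the other has no size. From the compounds shown here alone, whether a benzyl group or an octyl chain on this ring nitrogen would give a lower number than hexyl in compound 2 stays open.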